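Inverting the ring stereocentre of compound 1

A few compounds are considered here, and "the series" means these few. Any claim that something is new, unique, unknown or untested is made for them only; others in the source may bear on it.

Measured compounds:
compound 1, `CC1=C(c2cccc(O)c2)[C@H](c2ccc(OC[C@H](C)N3CC[C@@H](C)C3)cc2)Oc2ccc(O)cc21`, 0.1 nM
compound 2, `CC1=C(c2cccc(O)c2)C(c2ccc(OC[C@@H](C)N3CCCC3)cc2)Oc2ccc(O)cc21`, 0.2 nM
compound 3, `CC1=C(c2ccc(O)cc2)C(c2ccc(OC[C@H](C)N3CC[C@@H](C)C3)cc2)Oc2ccc(O)cc21`, 0.1 nM

In a functional assay on MCF7 cells (Homo sapiens) for antiproliferative activity, read by CellTiter-Glo, with a stated time of 5 days (on this read-out higher numbers stand for weaker inhibition and lower numbers for stronger inhibition), compound 1 gives 0.1 nM. It stands level with compound 3, and the two together are the lowest of the three numbers; compound 2 is the furthest away, though its gap from compound 1 lies within the scatter. No single change between measured compounds is available to set a scale.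

Compound 4, `CC1=C(c2cccc(O)c2)[C@@H](c2ccc(OC[C@H](C)N3CC[C@@H](C)C3)cc2)Oc2ccc(O)cc21`, has not been measured. Its difference from compound 1 is the two compounds have the same atoms and bonds and differ only in configuration as drawn: 1 of 3 stereo elements differ; a stereocentre at a saturated ring carbon is drawn S in compound 1 and R in compound 4. Compounds 2 and 3 carry no drawn configuration at this carbon, so nothing here shows what one configuration alone does. Still, the expected direction is weaker inhibition, and the expected step from compound 1 to compound 4 is a 20-fold higher number from compound 1 to compound 4 (1.30 log units; beyond the scatter). Compound 4 is estimated at 2 nM, with a range from 0.2 nM to 30 nM.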

Compound 4, half-maximal inhibitory concentration: 59 nM
The estimate for compound 4 lay 30-fold (1.47 log units) below the measured number; measured number outside the range, above it.
By their numbers in this assay, from the lowest: compounds 1, 3 and 2 (each within the scatter of the next); then compound 4.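

At this saturated ring carbon, configuration alone has a large effect in this assay: going from S to R gives a 590-fold higher number from compound 1 to compound 4 (2.77 log units; beyond the scatter). The earlier compounds shown here could not show this, as compounds 2 and 3 carry no drawn configuration at this carbon. The gap traces to this single stereocentre, and the support for that is: the fact that compounds 1 and 4 differ only in the configuration as drawn

It remains open which configuration or mixture lies behind the numbers for compounds 2 and 3. Also open, on these data alone, is whether the R configuration would cost as much with a carboxylic acid in place of the amine.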